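Adding One Chloro to Compound 3

A few compounds are considered here, and "the series" means these few. Any claim that something is new, unique, unknown or untested is made for them only; others in the source may bear on it.

In a functional assay on SK-MEL-2 cells (Homo sapiens) for cytotoxicity (a higher number here means a weaker inhibitor, a lower number a stronger inhibitor), compound 1 `O=C1NC(c2ccc(Cl)cc2)CN1S(=O)(=O)c1ccc2c(c1)CCC2` gives 64300 nM, compound 2 `O=C1NCC(c2ccc(Br)cc2)N1S(=O)(=O)c1ccc(Cl)cc1` gives 106000 nM, and compound 3 `Cc1ccc(C2CNC(=O)N2S(=O)(=O)c2ccccc2)cc1` gives 144000 nM. Compound 3 sits level with compound 2, within the scatter, while its number is higher than that of compound 1, beyond the scatter. Compound 4 `Cc1ccc(C2CNC(=O)N2S(=O)(=O)c2ccc(Cl)cc2)cc1` differs from compound 3 by one change: chloro in place of hydrogen on an aromatic carbon. This places chloro in place of hydrogen on an aromatic carbon, turning phenyl into 4-chlorophenyl. Among the measured compounds shown here, no measured pair shows this change alone. Compound 2 already carries a 4-chlorophenyl on its sulfonyl group and gives 106000 nM, close to compound 3. Expected is a small move toward a lower number, a 1.4-fold lower number from compound 3 to compound 4 (0.14 log units; within the scatter), within the scatter. For compound 4 the estimated value is 105000 nM, with an expected range from 60000 nM to 180000 nM.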

Compound 4, half-maximal inhibitory concentration: 255000 nM
Compound 4: the middle estimate sits 2.4-fold (0.39 log units) below what was measured; the measured number lies above the stated range.
By their numbers in this assay, from the lowest: compounds 1, 2, 3 and 4 (each within the scatter of the next, the first and the last beyond it).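

In this assay, the first direct test of chloro in place of hydrogen, on the aromatic carbon para to a large group, gives a 1.8-fold higher number from compound 3 to compound 4 (0.25 log units; within the scatter), so this change leaves the number level with that of compound 3. With 4-chlorophenyl held fixed on the sulfonyl group, methyl in place of bromo on the other aromatic ring gives a 2.4-fold higher number from compound 2 to compound 4 (0.38 log units; beyond the scatter), a modest step beyond the scatter. Nothing available here gives a reason for either step. Still open, on these data alone, is whether an amine or a carboxylic acid at the chloro position would move the number.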